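A few compounds are considered here, and "the series" means these few. Any claim that something is new, unique, unknown or untested is made for them only; others in the source may bear on it.

Measured in a functional assay on A549 cells (Homo sapiens) for cytotoxicity, read by MTT assay, with a stated time of 72 h; on this read-out higher numbers stand for an effect only at larger amounts of compound and lower numbers for an effect already at smaller amounts:
- compound 1 `CCc1cccc2c(O)c(-c3occ(C)c3C(=O)O)ccc12`: 10.6 ug/mL
- compound 2 `CCc1cccc2c(OC)c(-c3occ(C)c3C(=S)OC)ccc12`: 6.2 ug/mL

Compound 2 lies within the scatter of compound 1 in this assay, so these two values do not separate the pair. Compound 3 `CCc1cccc2c(OC)c(-c3occ(C)c3CBr)ccc12` is the next entry, with a group of 2 heavy atoms (1 carbon, 1 bromine; no ring) in place of a group of 4 heavy atoms (2 carbon, 1 oxygen, 1 sulfur; no ring), on an aromatic carbon. The bromomethyl stands on an aromatic carbon of a five-membered aromatic ring with 1 oxygen. Going by the values given here, no measured pair covers this exchange, so the expectation is loose. The estimated change is a 1.4-fold lower number from compound 2 to compound 3 (0.14 log units; within the scatter), a modest move to lower numbers that may stay within the scatter. For compound 3 the expected value is 4.5 ug/mL, with an estimated range of 1.5 ug/mL to 12 ug/mL.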

Compound 3, concentration for half-maximal effect: > 10 ug/mL
Compound 3: no number, only a limit; the forecaster's own chance of this, stated with the estimate: 5%; at least 2.2-fold (0.34 log units) between middle value and limit.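

In this assay compound 3 gives only a limit, > 10 ug/mL, and not a number. Bromomethyl on this aromatic carbon of the five-membered ring gives the first one-place step at this position: an at least 1.6-fold higher number from compound 2 to compound 3 (0.20 log units; that floor lies within the scatter). No move to lower numbers appears with this exchange, yet the floor alone does not separate the pair.

From the compounds shown here alone, the true size of the step stays open. Also open, going by these compounds, is how an aminomethyl group or a primary amide would read on this same carbon.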